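The source may hold more compounds than are shown below. What is called first, only, known or untested is meant among the compounds shown, and "the series" means these compounds.

Compound 1 `Nc1scc(-c2cccc(C(F)(F)F)c2)c1C(=O)c1ccccc1` is the smallest member of this set, and in a functional assay on CHO-K1 cells for agonist activity at adenosine receptor A1 (Homo sapiens), read by GTPgammaS binding (a lower number here means that less compound is needed, a higher number that more compound is needed for the effect), compound 1 gives 15.8 uM. Compound 2 `CC(=O)c1cccc(-c2sc(N)c(C(=O)c3ccccc3)c2-c2cccc(C(F)(F)F)c2)c1` adds a 3-acetylphenyl group to the shared core; in this assay compound 2 reaches only the limit of > 10 uM. Compound 3 `CCOC(=O)c1c(N)sc(-c2cccc(C(C)=O)c2)c1-c1cccc(C(F)(F)F)c1` carries an ethoxy group where compound 2 carries a phenyl on the carbonyl carbon; in this assay compound 3 likewise stands at the limit of > 10 uM. The step that the limit leaves unreadable from compound 1 to compound 2 and the step that the two limits leave unreadable from compound 2 to compound 3 cannot be sized because of the limit of > 10 uM in this assay, at which 2 of the 3 values shown sit. Compound 3 therefore stands at the limit together with compound 2, and only compound 1 has a value that is a number. Compound 4 `CCOC(=O)c1c(N)sc(-c2ccc(C(F)(F)F)cc2)c1-c1cccc(C(F)(F)F)c1` differs from compound 3 by 4-(trifluoromethyl)phenyl in place of 3-acetylphenyl on an aromatic carbon. Within the data shown here, no measured step concerns an exchange of one aryl group for another at this position, so the expectation for compound 4 can rest only on where compound 3 stands. The expected step that the limit leaves unreadable from compound 3 to compound 4 is small. Compound 4 is estimated at 20 uM, with a range from 5 uM to 80 uM.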

Compound 4, concentration for half-maximal effect: > 10 uM
Compound 4: a limit, no number (the forecaster's own chance of this, stated with the estimate: 70%); the middle value does not contradict the limit.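

Among these compounds, compound 3 and compound 4 both stand at a limit rather than a number, so no step between them can be read: the limit of > 10 uM in this assay, at which 3 of the 4 values shown sit. The compounds shown leave open what numbers lie behind these limits, and so whether exchanging 3-acetylphenyl for 4-(trifluoromethyl)phenyl changes the concentration needed at all.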